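Swapping the thiazolyl for fluorophenyl on the shared core

This account rests on a few compounds, and the source may have more. Where it says the series, first, only, none or still open, it means among the compounds named here.

For the measured compounds named here, compound 2 `COc1nc(-c2cnsc2)ccc1[C@@H](c1ccccc1)[C@@](O)(CCN(C)C)c1cccc2ccccc12` is the only member of this small set with a number in a toxicity assay on Vero cells (Chlorocebus sabaeus) for cytotoxicity; on this read-out higher numbers stand for lower toxicity in this test and lower numbers for higher toxicity in this test: in this assay compound 2 gives 26.3 ug/mL. Compound 1 `COc1nc(C2CCOCC2)ccc1[C@@H](c1ccccc1)[C@@](O)(CCN(C)C)c1cccc2ccccc12` is the reference partner; in this assay compound 1 gives > 50 ug/mL, which is a limit of the assay rather than a number. Going by the values given here, the one measured step is an at least 1.9-fold lower number from compound 1 to compound 2 (0.27 log units; that floor lies within the scatter), and its floor sits at the limit of > 50 ug/mL in this assay, at which 1 of the 2 values shown sits.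

Compound 3 `COc1nc(-c2ccc(F)cc2)ccc1[C@@H](c1ccccc1)[C@@](O)(CCN(C)C)c1cccc2ccccc12` has not yet been measured in this assay. Its change from compound 2 is 4-fluorophenyl in place of 1,2-thiazol-4-yl on an aromatic carbon. This change occurs at the same aromatic carbon as the measured step, so that step is the only one that bears on it; its size could not be resolved beyond the floor, and it gives no direction for a six-membered carbon ring entering in place of a five-membered ring with two hetero atoms. The author therefore expects no step beyond the usual scatter, estimating a 1.3-fold lower number from compound 2 to compound 3 (0.12 log units; within the scatter). For compound 3 the estimated value in this assay is 20 ug/mL, with a range from 8 ug/mL to 50 ug/mL.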

Compound 3, half-maximal cytotoxic concentration: > 50 ug/mL
Compound 3: no number, only a limit; the forecaster's own chance of this, stated with the estimate: 25%; middle value at least 2.5-fold (0.39 log units) from the limit.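

In this assay compound 3 gives > 50 ug/mL, which is a limit of the assay and not a number. Placing 4-fluorophenyl on this aromatic carbon, next to the ring nitrogen, in place of 1,2-thiazol-4-yl gives an at least 1.9-fold higher number from compound 2 to compound 3 (0.27 log units; that floor lies within the scatter), so a measurable number at this position does not come with every aromatic ring, although the floor of this step cannot separate the two compounds beyond the scatter. The step between compound 1 and compound 3 cannot be read, which leaves oxan-4-yl and 4-fluorophenyl unranked and compound 2 as the only compound with a number: the limit of > 50 ug/mL in this assay, at which 2 of the 3 values shown sit.

The compounds shown leave open how far compound 1 and compound 3 lie past their limits, and so whether the step from compound 2 is larger than its floor. They also leave open whether the number of compound 2 goes with the ring sulfur, the ring nitrogen or the five-membered ring itself, which a thiophen-3-yl or a pyridin-3-yl group at this carbon would begin to separate, and how an amine or a carboxylic acid would read there.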